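The source may hold more compounds than are shown below. What is called first, only, known or untested is meant among the compounds shown, and "the series" means these compounds.

Series notes, aryl tail on the saturated chain of the shared core. Among the measured compounds shown here, compound 1 `CCn1nc(C)c2c1CCN(C(C(=O)NC)c1ccccc1)C2CCc1ccc(Cl)cc1` gives 12 nM in a functional assay on CHO cells for antagonist activity at Orexin receptor type 2 (Homo sapiens), read by FLIPR and calcium flux (a lower number here means a stronger inhibitor, a higher number a weaker inhibitor), and stands second highest of the three numbers so far. Compound 2 `CCn1nc(C)c2c1CCN(C(C(=O)NC)c1ccccc1)C2CCc1cccc(C(F)(F)F)c1` gives 7 nM in this assay, and compound 3 `CCn1nc(C)c2c1CCN(C(C(=O)NC)c1ccccc1)C2CCc1ccccc1F` gives 22 nM in this assay. The steps of a 1.7-fold lower number from compound 1 to compound 2 (0.23 log units; within the scatter) and a 1.8-fold higher number from compound 1 to compound 3 (0.26 log units; within the scatter) both stay within the scatter; only a 3.1-fold higher number from compound 2 to compound 3 (0.50 log units; beyond the scatter) passes beyond it, and modestly so. Compound 4 `CCn1nc(C)c2c1CCN(C(C(=O)NC)c1ccccc1)C2CCc1cccc(C)c1` is not yet measured. It differs from compound 1 thus: 3-methylphenyl in place of 4-chlorophenyl on a saturated chain carbon, two bonds along the chain from a saturated ring carbon. For the measured compounds named here, the steps that bear on this change are the two aryl swaps from compound 1, a 1.7-fold lower number from compound 1 to compound 2 (0.23 log units; within the scatter) and a 1.8-fold higher number from compound 1 to compound 3 (0.26 log units; within the scatter), both small. Going by the values given here, no measured pair separates 3-methylphenyl from 3-(trifluoromethyl)phenyl, so the direction rests on compound 2 alone. For compound 4 the step of a 1.2-fold lower number from compound 1 to compound 4 (0.08 log units; within the scatter) is expected, which is not beyond the scatter in this assay. Compound 4 is therefore estimated at 10 nM, with a range from 4 nM to 25 nM.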

Compound 4, half-maximal inhibitory concentration: 19 nM
Estimate against measurement, compound 4: 1.9-fold (0.28 log units) below; low and high end bracket the measured number.
By their numbers in this assay, from the lowest: compounds 2, 1, 4 and 3 (each within the scatter of the next, the first and the last beyond it).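

In this assay, among the compounds shown here, the step of a 2.7-fold higher number from compound 2 to compound 4 (0.43 log units; beyond the scatter) is modest, and it is the first one here in which only the group on an aromatic carbon changes, methyl in place of trifluoromethyl, while the rest of the aryl tail stays the same. The steps of a 1.6-fold higher number from compound 1 to compound 4 (0.20 log units; within the scatter) and a 1.2-fold lower number from compound 3 to compound 4 (0.06 log units; within the scatter) both stay within the scatter, so of the aryl tails compared, only 3-(trifluoromethyl)phenyl is separated from 3-methylphenyl. No measurement at hand accounts for the step from trifluoromethyl to methyl.

The compounds shown leave open how other groups on that aromatic carbon, such as methoxy or a nitrile, would compare with methyl and trifluoromethyl. They also leave open how the series would respond to a longer chain carrying the aryl tail.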